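This account rests on a few compounds, and the source may have more. Where it says the series, first, only, none or still open, it means among the compounds named here.

Compound 2 `COc1cc(CN(C)C(=O)c2c(OCCCC3CCN(C(=O)OC4(C)CC4)CC3)c3cccnc3n(C)c2=O)cc(OC)c1` and compound 1 `CN(Cc1cc(C(F)(F)F)cc(C(F)(F)F)c1)C(=O)c1c(OCCCC2CCN(C(=O)OC3(C)CC3)CC2)c2cccnc2n(C)c1=O` share the same core and differ only in the substituted phenyl ring on the amide. In an assay for inhibition of phosphatidylcholine:ceramide cholinephosphotransferase 2 (Mus musculus), read by mass spectrometry, with stated times of 60 min and 30 min (a lower number here means a stronger inhibitor, a higher number a weaker inhibitor), compound 2 gives 14 nM, the higher of the two numbers recorded, whereas compound 1 gives 3 nM. Compound 3 `COc1cc(CN(C)C(=O)c2c(OCCCC3CCN(C(=O)OC4(C)CC4)CC3)c3cccnc3n(C)c2=O)cc(C(F)(F)F)c1` carries trifluoromethyl in place of methoxy on an aromatic carbon. Within the data shown here, no step between measured compounds has been recorded, so the expectation rests on compound 1 and compound 2 alone. With one trifluoromethyl and one methoxy, compound 3 is expected to land between them, and the step of a 2.3-fold lower number from compound 2 to compound 3 (0.37 log units; beyond the scatter) is expected to lower the number beyond the scatter. Compound 3 is estimated at 6 nM in this assay, within 2.5 nM to 15 nM.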

Compound 3, half-maximal inhibitory concentration: 2.2 nM
Beside the measured number, compound 3's estimate is 2.7-fold (0.44 log units) above it, and the stated range ends above it.
By their numbers in this assay, from the lowest: compounds 3 and 1 (each within the scatter of the next); then compound 2.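

In this assay, a single change from 3,5-dimethoxyphenyl to 3-methoxy-5-(trifluoromethyl)phenyl gives a 6.4-fold lower number from compound 2 to compound 3 (0.80 log units; beyond the scatter), so one trifluoromethyl at this position is enough for a step beyond the scatter. Among these compounds, exchanging the remaining methoxy for a second trifluoromethyl gives no step that can be told apart, as the reverse change gives a 1.4-fold lower number from compound 1 to compound 3 (0.13 log units; within the scatter), within the scatter. Nothing available explains either step.

The compounds shown leave open whether this step is specific to trifluoromethyl or would also appear with chlorine, methyl or a nitrile. They also leave open what a ring with hydrogen in place of the remaining methoxy would give.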